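Swapping the furan-2-yl group for 2-fluoropyridin-4-yl: a cytotoxicity estimate

The compounds below may be only part of what the source reports. "The series", "measured", "known", "first", "only" and "open" are said of these compounds alone.

Three compounds have been measured in a toxicity assay on MT4 cells (Homo sapiens) for cytotoxicity, read by MTT assay, with a stated time of 5 days (a lower number here means that less compound is tolerated, a higher number that more compound is tolerated), so far

Compound 1 `Cc1cnc(Nc2ccc(C#N)cc2)nc1Nc1c(F)cc(-c2cncnc2)cc1F` gives 900 nM
Compound 2 `Cc1cnc(Nc2ccc(C#N)cc2)nc1Nc1c(F)cc(-c2ccco2)cc1F` gives 8100 nM
Compound 3 `Cc1cnc(Nc2ccc(C#N)cc2)nc1Nc1c(F)cc(-c2ccsc2)cc1F` gives 261000 nM

Compound 2 stands second highest of the three numbers. The steps that frame it are a 9.0-fold higher number from compound 1 to compound 2 (0.95 log units; beyond the scatter) and a 32-fold higher number from compound 2 to compound 3 (1.51 log units; beyond the scatter) and both lie beyond the scatter. Compound 4 `Cc1cnc(Nc2ccc(C#N)cc2)nc1Nc1c(F)cc(-c2ccnc(F)c2)cc1F` has not yet been measured. Relative to compound 2 it shows 2-fluoropyridin-4-yl in place of furan-2-yl on an aromatic carbon in a single place, on an aromatic carbon. Within the data shown here, no measured step covers this exchange directly. The closest guide is compound 1 at 900 nM since its pyrimidin-5-yl group is the only other six-membered ring at this place. Compound 3 warns against a narrow range, with a 290-fold higher number from compound 1 to compound 3 (2.46 log units; beyond the scatter) at the same place. In this assay no step beyond the scatter is therefore expected, with a lean towards a lower number. The expected step is a 1.6-fold lower number from compound 2 to compound 4 (0.21 log units; within the scatter) by this estimate. For compound 4 the estimated value is 5000 nM with an expected range from 1000 nM to 30000 nM in most repeat measurements.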

Compound 4, half-maximal cytotoxic concentration: 167000 nM
Estimate against measurement, compound 4: 33-fold (1.52 log units) below, and the stated range ends below it.
By their numbers in this assay, from the lowest: compound 1; then compound 2; then compounds 4 and 3 (each within the scatter of the next).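

In this assay, a six-membered aromatic ring at this place does not by itself keep the number low, since a 190-fold higher number from compound 1 to compound 4 (2.27 log units; beyond the scatter) separates two compounds that both carry such a ring. Placing 2-fluoropyridin-4-yl where furan-2-yl stood gives a 21-fold higher number from compound 2 to compound 4 (1.31 log units; beyond the scatter), while a 1.6-fold lower number from compound 3 to compound 4 (0.19 log units; within the scatter) shows that a six-membered ring and the five-membered thiophen-3-yl can stand level here, so neither ring size nor the count of ring hetero atoms orders these four compounds. No measurement at hand accounts for these differences.

The compounds shown leave open what a plain pyridin-4-yl group would give at this place, and so whether the fluorine goes with the gap. They also leave open how a saturated ring such as morpholine would behave here.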